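The source may hold more compounds than are shown below. What is called first, only, known or untested is meant among the compounds shown, and "the series" means these compounds.

Of the compounds shown here, three have been measured in an assay for binding affinity to melatonin receptor type 1B (Gallus gallus), read by radioligand binding; on this read-out higher numbers stand for weaker inhibition and lower numbers for stronger inhibition. Compound 1, `CCCC(=O)NCC1CCCc2ccc(OC)cc21`, gives 0.45 nM. Compound 2, `COc1ccc2c(c1)C(CNC(C)=O)C2`, gives 224 nM. Compound 3, `COc1ccc2c(c1)C(CNC(C)=O)CCCC2`, gives 34 nM, the second highest of the three numbers: compound 2 sits above it, and compound 1 lies far below it. Compound 3 and compound 1 differ in more than one place, so those two values only show that the longer chain of compound 1 goes together with the much lower number.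

Compound 4, `CCC(=O)NCC1CCCCc2ccc(OC)cc21`, has not been measured. It differs from compound 3 in a single place: methyl in place of hydrogen on a saturated chain carbon bound to a carbonyl carbon. With nothing else changed, the step is expected to be modest and to run downward, toward a lower number, because compound 1 with its longer acyl chain gives 0.45 nM. Compound 4 is therefore estimated at 10 nM in this assay, with a likely range of 3 nM to 40 nM. That estimate means a step of a 3.4-fold lower number from compound 3 to compound 4 (0.53 log units; beyond the scatter), somewhat beyond the scatter.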

Compound 4, inhibition constant: 29 nM
Estimate against measurement, compound 4: 2.9-fold (0.46 log units) below; low and high end bracket the measured number.
By their numbers in this assay, from the lowest: compound 1; then compounds 4 and 3 (each within the scatter of the next); then compound 2.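

In this assay, among the compounds shown here, the change from acetamido to propanoylamino, with the rest of the molecule untouched, gives a 1.2-fold lower number from compound 3 to compound 4 (0.07 log units; within the scatter) and is the first single-place step available in this set. Methyl in place of hydrogen on a saturated chain carbon bound to a carbonyl carbon therefore makes no difference here that can be told apart from the ordinary spread of repeated measurements, so on this core the one added carbon does not register. Nothing shown gives a reason for this flat step. Still open, from the compounds shown here alone, is whether a longer chain such as pentanoyl, or a ring such as cyclopropyl, in this place would shift the number on this core. Also open, going by these compounds, is whether the same methyl step would read the same way on the core of compound 1 or on that of compound 2.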